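Chloro to fluoro on the sulfonamide ring: compound 4

A few compounds are considered here, and "the series" means these few. Any claim that something is new, unique, unknown or untested is made for them only; others in the source may bear on it.

Values in an ADME assay on RAW264.7 cells (Mus musculus) for cytotoxicity, read by MTT assay, with a stated time of 48 h (on this read-out higher numbers stand for weaker inhibition and lower numbers for stronger inhibition), for the measured compounds:
compound 1 `CS(=O)(=O)Nc1ccc(NC(=O)c2ccc(Cl)c([N+](=O)[O-])c2)cc1Cl`: 43600 nM
compound 2 `O=C(Nc1ccc(NS(=O)(=O)C(F)(F)F)c(Cl)c1)c1ccc(Cl)cc1`: 47200 nM
compound 3 `O=C(Nc1ccc(NS(=O)(=O)C(F)(F)F)c(Cl)c1)c1ccc(Cl)c([N+](=O)[O-])c1`: 31700 nM

Compound 3 sits within the scatter of both other measured compounds: a 1.4-fold lower number from compound 1 to compound 3 (0.14 log units; within the scatter), and a 1.5-fold lower number from compound 2 to compound 3 (0.17 log units; within the scatter). Neither exchange, on the sulfonyl sulfur or on the benzoyl ring, moved the number beyond repeat variation, so the three measured compounds show a flat series in this assay.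

Compound 4 `O=C(Nc1ccc(NS(=O)(=O)C(F)(F)F)c(F)c1)c1ccc(Cl)c([N+](=O)[O-])c1` differs from compound 3 by fluoro in place of chloro on an aromatic carbon. Within the data shown here, no measured step concerns a halogen exchange on this carbon, so nothing bears on it directly; the only guide is that the two changes already seen on neighbouring parts of the core left the number unchanged within the scatter. The expected step in this assay is therefore none beyond the scatter: a 1.1-fold higher number from compound 3 to compound 4 (0.04 log units; within the scatter) is the estimate. Compound 4 is accordingly expected to give about 35000 nM in this assay, with a likely range from 15000 nM to 80000 nM.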

Compound 4, half-maximal inhibitory concentration: 188000 nM
For compound 4 the middle estimate is 5.4-fold (0.73 log units) below the measured one; measured number outside the range, above it.
By their numbers in this assay, from the lowest: compounds 3, 1 and 2 (each within the scatter of the next); then compound 4.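

In this assay, among these compounds, this position gives the first single exchange to move the number beyond the scatter: fluoro in place of chloro, ortho to the ((trifluoromethyl)sulfonyl)amino group, gives a 5.9-fold higher number from compound 3 to compound 4 (0.77 log units; beyond the scatter). The flat picture from the exchanges on the sulfonyl sulfur and the benzoyl ring therefore does not extend to this carbon, where replacing one halogen with another, with no change in rings, hydrogen-bond donors, hydrogen-bond acceptors or net charge, is enough to separate compound 4 from compound 3. No available evidence accounts for this step.

On these data alone, it remains open whether the step follows the arrival of fluoro or the loss of chloro; bromo or methoxy on this carbon would help separate the two readings. Also open, as far as these compounds go, is whether the step persists with methyl on the sulfonyl sulfur or without the nitro group, as fluoro appears here only alongside trifluoromethyl and nitro.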